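Ethynyl Linker Swap on the Thiophene Core

The source may hold more compounds than are shown below. What is called first, only, known or untested is meant among the compounds shown, and "the series" means these compounds.

Compound 1, `C[C@H](NC(=O)c1c(Cc2cc(F)c(Cl)cc2Cl)sc2c1CCOC2)c1ccc(C(=O)O)cc1`: in a functional assay on CHO/Galpha16 cells for antagonist activity at prostaglandin E2 receptor EP4 subtype (Homo sapiens), read by calcium flux, with a stated time of 15 min (on this read-out higher numbers stand for weaker inhibition and lower numbers for stronger inhibition), compound 1 gives 2.5 nM.
Compound 2, `C[C@H](NC(=O)c1c(C#Cc2ccc(=O)[nH]c2)sc2c1CCOC2)c1ccc(C(=O)O)cc1`: compound 2 gives 642 nM.
Compound 3, `CC(C)c1ccc(Cc2sc3c(c2C(=O)N[C@@H](C)c2ccc(C(=O)O)cc2)CCOC3)cc1`: compound 3 gives 2.7 nM.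

Compound 3 holds the second highest number of the three; it sits within the scatter of compound 1 (a 1.1-fold higher number from compound 1 to compound 3 (0.03 log units; within the scatter)) and far from compound 2 (a 240-fold lower number from compound 2 to compound 3 (2.38 log units; beyond the scatter)). The unmeasured compound 4, `C[C@H](NC(=O)c1c(C#Cc2ccc(F)cc2)sc2c1CCOC2)c1ccc(C(=O)O)cc1`, differs from compound 3 by one change: 2-(4-fluorophenyl)ethynyl in place of 4-isopropylbenzyl on an aromatic carbon. Among the compounds with values here, two measured steps bear on it. The step of a 260-fold higher number from compound 1 to compound 2 (2.41 log units; beyond the scatter) and its reverse 240-fold lower number from compound 2 to compound 3 (2.38 log units; beyond the scatter) both pair an ethynyl-linked ring against a methylene-linked ring, while a 1.1-fold higher number from compound 1 to compound 3 (0.03 log units; within the scatter) shows that swapping the aryl part of a benzyl group changes little. Compound 4 keeps the ethynyl linker of compound 2 but carries a fluorophenyl rather than the pyridinone ring, and the data cannot separate the two effects. Compound 4 is therefore expected to give a higher number than compound 3, by a 15-fold higher number from compound 3 to compound 4 (1.17 log units; beyond the scatter), estimated at 40 nM with a range of 6 nM to 300 nM, because of the large step of a 240-fold lower number from compound 2 to compound 3 (2.38 log units; beyond the scatter).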

Compound 4, half-maximal inhibitory concentration: 15.8 nM
Compound 4: the middle estimate sits 2.5-fold (0.40 log units) above what was measured, within the range that was stated.
By their numbers in this assay, from the lowest: compounds 1 and 3 (each within the scatter of the next); then compound 4; then compound 2.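

In this assay, the triple bond at this position does not by itself bring the large loss seen with compound 2: with the linker held, 4-fluorophenyl in place of the ring with one hetero atom gives a 41-fold lower number from compound 2 to compound 4 (1.61 log units; beyond the scatter), so most of that gap goes with the ring at the end of the triple bond. Against the benzyl compounds, the 2-(4-fluorophenyl)ethynyl group leaves only a modest gap, with a 5.9-fold higher number from compound 3 to compound 4 (0.77 log units; beyond the scatter) and a 6.3-fold higher number from compound 1 to compound 4 (0.80 log units; beyond the scatter). Nothing available explains why these steps differ in size.

No two compounds shown carry the same ring on both linkers, so the effect of the triple bond alone remains open; a 4-fluorobenzyl group at this place would supply that pair. Going by these compounds, how an amine on the ring of the 2-(4-fluorophenyl)ethynyl group would read also stays unknown.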